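Replacing the carbonyl substituent of compound 1 with a small ring

This account rests on a few compounds, and the source may have more. Where it says the series, first, only, none or still open, it means among the compounds named here.

Measured compounds:
compound 1, `Cc1nc(S(C)(=O)=O)ccc1Oc1ncnc(OC2CCN(C(=O)OC(C)(C)C(F)(F)F)CC2)c1F`, 6.53 nM
compound 2, `Cc1nc(S(C)(=O)=O)ccc1Oc1ncnc(OC2CCN(C(=O)SC3CC3)CC2)c1F`, 24.9 nM
compound 3, `Cc1nc(S(C)(=O)=O)ccc1Oc1ncnc(OC2CCN(C(=O)C(C)(C)F)CC2)c1F`, 76.3 nM

In a functional assay on isolated protein for inhibition of Glucose-dependent insulinotropic receptor (Homo sapiens), read by HTRF and cAMP accumulation (a lower number here means that less compound is needed, a higher number that more compound is needed for the effect), compound 1 gives 6.53 nM, the lowest of the three numbers; the nearest is compound 2 with a 3.8-fold higher number from compound 1 to compound 2 (0.58 log units; beyond the scatter), the furthest compound 3 with a 12-fold higher number from compound 1 to compound 3 (1.07 log units; beyond the scatter). The unmeasured compound 4, `Cc1nc(S(C)(=O)=O)ccc1Oc1ncnc(OC2CCN(C(=O)C3(C)CC3)CC2)c1F`, differs from compound 1 only on the carbonyl carbon: 1-methylcyclopropyl in place of 1-methyl-1-(trifluoromethyl)ethoxy on a carbonyl carbon.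

Among the measured compounds shown here, three measured steps bear on this change, all on the same carbonyl carbon. Compound 1 to compound 2 exchanged the 1-methyl-1-(trifluoromethyl)ethoxy group for a ring-bearing group and gave a 3.8-fold higher number from compound 1 to compound 2 (0.58 log units; beyond the scatter). Compound 1 to compound 3 exchanged it for a group with no ring and gave a 12-fold higher number from compound 1 to compound 3 (1.07 log units; beyond the scatter). Between those two, compound 2 to compound 3 gave a 3.1-fold higher number from compound 2 to compound 3 (0.49 log units; beyond the scatter). Every replacement of the 1-methyl-1-(trifluoromethyl)ethoxy group in this set raised the number, and the group entering in compound 4 shares the three-membered ring with compound 2 and the lack of oxygen with compound 3. The step is therefore expected to be upward, beyond the scatter, of modest to large size: a 6.1-fold higher number from compound 1 to compound 4 (0.79 log units; beyond the scatter). For compound 4 the estimate in this assay is 40 nM, with a range from 15 nM to 120 nM.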

Compound 4, half-maximal effective concentration: 761 nM
Estimate against measurement, compound 4: 19-fold (1.28 log units) below; the whole stated range lies below it.
By their numbers in this assay, from the lowest: compound 1; then compound 2; then compound 3; then compound 4.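

In this assay the exchange of 1-methyl-1-(trifluoromethyl)ethoxy for 1-methylcyclopropyl on this carbonyl carbon gave a 120-fold higher number from compound 1 to compound 4 (2.07 log units; beyond the scatter), the largest step seen at this position, so the place is far less forgiving of change than the first three compounds showed. The three-membered ring alone does not keep the number low: compound 2 and compound 4 both carry one, yet the step between them is a 31-fold higher number from compound 2 to compound 4 (1.49 log units; beyond the scatter), and even the ring-free 1-fluoro-1-methylethyl group of compound 3 compares well with 1-methylcyclopropyl, with a 10-fold higher number from compound 3 to compound 4 (1.00 log units; beyond the scatter) as the step. Among these four compounds, the only group made of carbon alone gives the highest number, and no compound here goes against that, but nothing measured here gives a reason for the order.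

The compounds shown leave open whether the high number of compound 4 goes with the ring, with the missing oxygen or sulfur on the carbonyl carbon, or with the missing fluorine. A 1-(trifluoromethyl)cyclopropyl group or a 1-methylcyclopropoxy group on the same carbonyl carbon would begin to separate these readings, and neither stands among the four structures.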